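Nitro in place of chloro: compound 3 to compound 4

This account rests on a few compounds, and the source may have more. Where it says the series, first, only, none or still open, it means among the compounds named here.

In a functional assay on NCI-H727 cells (Homo sapiens) for cytotoxicity, with a stated time of 48 h (a lower number here means a stronger inhibitor, a higher number a weaker inhibitor), compound 1 (`COc1cc(OC)c(C(=O)/C=C/c2ccccc2SC)c(OC)c1`) gives 8700 nM, compound 2 (`COc1cc(OC)c(C(=O)/C=C/c2ccccc2)c(OC)c1`) gives 11400 nM and compound 3 (`COc1cc(OC)c(C(=O)/C=C/c2ccc(Cl)cc2)c(OC)c1`) gives 6000 nM. Compound 3 therefore stands within the scatter of both others, as the step of a 1.5-fold lower number from compound 1 to compound 3 (0.16 log units; within the scatter) also shows.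

Compound 4 (`COc1cc(OC)c(C(=O)/C=C/c2ccc([N+](=O)[O-])cc2)c(OC)c1`) follows from compound 3 by one change: nitro in place of chloro on an aromatic carbon. The nearest measured change, chloro in place of hydrogen, is a 1.9-fold lower number from compound 2 to compound 3 (0.28 log units; within the scatter). Removing methylsulfanyl gives a 1.3-fold higher number from compound 1 to compound 2 (0.12 log units; within the scatter). Going by the values given here, neither leaves the scatter, and no measured compound carries nitro. No step beyond the scatter is therefore expected in this assay. The expected step is a 1.1-fold lower number from compound 3 to compound 4 (0.04 log units; within the scatter). For compound 4 the estimated value is 5500 nM, with an expected range of 2200 nM to 13000 nM.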

Compound 4, half-maximal inhibitory concentration: 4100 nM
Compound 4: the middle estimate sits 1.3-fold (0.13 log units) above what was measured; the measured number falls inside the stated range.
By their numbers in this assay, from the lowest: compounds 4, 3, 1 and 2 (each within the scatter of the next, the first and the last beyond it).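

In this assay, nitro in place of chloro on this aromatic carbon, para to a large group, gives a 1.5-fold lower number from compound 3 to compound 4 (0.17 log units; within the scatter), so the two groups stay within the scatter of each other. Going by these compounds alone, measured from hydrogen at the same place, nitro gives a 2.8-fold lower number from compound 2 to compound 4 (0.44 log units; beyond the scatter), the first step beyond the scatter, whereas chloro gives a 1.9-fold lower number from compound 2 to compound 3 (0.28 log units; within the scatter). No measurement bears on the reason for this modest step. On these data alone, whether an amine or a carboxylic acid at this place would also move beyond the scatter from hydrogen remains open.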